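Acetyl to benzoyl on the shared core

The compounds below may be only part of what the source reports. "The series", "measured", "known", "first", "only" and "open" are said of these compounds alone.

In a functional assay on MKN-45 cells (Homo sapiens) for cytotoxicity (a higher number here means a weaker inhibitor, a lower number a stronger inhibitor), compound 1 (`COc1ccc(S(=O)(=O)N2CCc3cccc(NC(=O)c4ccc([N+](=O)[O-])cc4)c32)cc1`) gives 95 nM and compound 2 (`COc1ccc(S(=O)(=O)N2CCc3cccc(NC(C)=O)c32)cc1`) gives 61 nM. The two values are not separated: a 1.6-fold lower number from compound 1 to compound 2 (0.19 log units; within the scatter) stays within the scatter, so compound 2 stands level with compound 1 on the available numbers.

Compound 3 (`COc1ccc(S(=O)(=O)N2CCc3cccc(NC(=O)c4ccccc4)c32)cc1`) is not yet measured. Relative to compound 2, it carries this change: phenyl in place of methyl on a carbonyl carbon. In short, phenyl in place of methyl on a carbonyl carbon, or acetamido to benzamido.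

Among the compounds with values here, only one measured step bears on this change. The step from compound 1 to compound 2 exchanges 4-nitrophenyl for methyl at the same carbonyl carbon, so it runs roughly opposite to the new change, with an aryl group and methyl again the two partners. That step is small, and a single pair gives only limited guidance. No shift beyond the scatter is therefore expected in this assay, and no direction is favoured with confidence. The estimated change is a 1.3-fold higher number from compound 2 to compound 3 (0.12 log units; within the scatter), which is expected to remain within the scatter. For compound 3 the estimated value is 80 nM, with an expected range of 35 nM to 180 nM.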

Compound 3, half-maximal inhibitory concentration: 250 nM
Beside the measured number, compound 3's estimate is 3.1-fold (0.49 log units) below it; the measured number lies above the stated range.
By their numbers in this assay, from the lowest: compounds 2 and 1 (each within the scatter of the next); then compound 3.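

In this assay the carbonyl carbon turns out to be sensitive to the group it carries: phenyl in place of methyl gives a step beyond the scatter (a 4.1-fold higher number from compound 2 to compound 3 (0.61 log units; beyond the scatter)), which the earlier level pair of compounds, one carrying 4-nitrophenyl and one carrying methyl, could not reveal. Hydrogen in place of nitro on an aromatic carbon also gives a step beyond the scatter (a 2.6-fold higher number from compound 1 to compound 3 (0.42 log units; beyond the scatter)), so an aryl group on this carbonyl does not set the number by itself, and among these three compounds only compound 3, with its unsubstituted phenyl, stands apart. Nothing available accounts for this separation, and no measurement explains why removing the nitro group moves the number while exchanging the whole 4-nitrophenyl group for methyl does not.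

Open, from the compounds shown here alone, is whether the nitro group is special or whether other groups at that aromatic carbon, such as an amine or a fluorine, would also return the number to the level of compound 1. Also open, going by these compounds, is how the carbonyl position responds to groups of intermediate size, such as a propyl chain or a cyclopropyl ring, in place of methyl or phenyl.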